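This account rests on a few compounds, and the source may have more. Where it says the series, first, only, none or still open, it means among the compounds named here.

Measured so far:
Compound 1 `CSc1ccc(CNc2nc(SC)nc3ncccc23)cc1` gives 9130 nM in a functional assay on MCF7 cells (Homo sapiens) for cytotoxicity, read by MTT assay, with a stated time of 72 h; a lower number here means that less compound is tolerated, a higher number that more compound is tolerated.
Compound 2 `CCCCC[Se]c1nc(NCc2ccc(SC)cc2)c2ccccc2n1` gives 95300 nM.
Compound 3 `Sc1nc(NCc2ccccc2)c2ccccc2n1` gives > 100000 nM, which is a limit of the assay rather than a number.

Among the two actual numbers, compound 1 has the lowest, meaning it is the least tolerated by the cells; compound 2 sits at a clearly higher number, a gap well beyond the usual scatter of repeated measurements. Compound 3 reaches only the limit described in the limit of > 100000 nM in this assay, at which 1 of the 3 values shown sits.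

Compound 4 `COc1ccc(CNc2nc(SC)nc3ncccc23)cc1` is not yet measured. It differs from compound 1 in one place: methoxy in place of methylsulfanyl on an aromatic carbon. Both groups carry one hydrogen-bond acceptor and no donor, so the change swaps one small para group for another of the same size.

No comparable swap has been measured here, so the expectation rests on the small size of the change alone. In this assay the step of a 1.3-fold higher number from compound 1 to compound 4 (0.12 log units; within the scatter) is expected to stay within the usual scatter, with no direction favoured. Compound 4 is therefore expected to give about 12000 nM, with a likely range from 4000 nM to 40000 nM.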

Compound 4, concentration lethal to 50% of the cells: > 100000 nM
Compound 4 gave a limit, no number; the forecaster's own chance of this, stated with the estimate: 5%; middle value at least 8.3-fold (0.92 log units) away from the limit.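

At this place on the aromatic ring, para to a large group, replacing methylsulfanyl with methoxy is far from a neutral swap, even though the two groups match in their counts of heavy atoms and hydrogen-bond acceptors: in this assay the change gives an at least 10-fold higher number from compound 1 to compound 4 (1.03 log units; beyond the scatter). Going by these compounds alone, no earlier pair differed in one place, so this is the first direct sign that the cell read-out of compound 1 depends on the group at this position. Compound 4 gives a limit of the assay rather than a number, and that limit is shared with another compound: the limit of > 100000 nM in this assay, at which 2 of the 4 values shown sit.

From the compounds shown here alone, how a chlorine, an amine or a longer ethylsulfanyl chain at this place would read remains open. Going by these compounds, the full size of the step also remains open, as one end of it is a limit.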